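Pyrazolyl chain end replacing phenethyl on the shared core

This account rests on a few compounds, and the source may have more. Where it says the series, first, only, none or still open, it means among the compounds named here.

Compound 2 `CCCCNc1nc(N)nc(C)c1CCCCCc1ccccc1` carries the shared core of compound 1 `CCCCNc1nc(N)nc(C)c1CCCCO` with a benzyl in place of the hydroxy on the side chain. Going by the values given here, in an assay on HEK293 cells for agonist activity at Toll-like receptor 8 (Homo sapiens), read by spectrophotometry (a higher number here means that more compound is needed for the effect, a lower number that less compound is needed), compound 2 gives 830 nM, the lowest of the two numbers so far; its nearest neighbour is compound 1, which in this assay gives 1310 nM, and the two are within the scatter of each other. Among the compounds with values here, the only measured step, a 1.6-fold lower number from compound 1 to compound 2 (0.20 log units; within the scatter), was made four bonds along the chain from an aromatic carbon and did not reach beyond the scatter.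

Compound 3 `CCCCNc1nc(N)nc(C)c1CCCn1cccn1` differs from compound 2 by 1H-pyrazol-1-yl in place of phenethyl on a saturated chain carbon, three bonds along the chain from an aromatic carbon. Within the data shown here, no measured step concerns this position or this kind of exchange, so nothing bears on it directly; the one step available, a 1.6-fold lower number from compound 1 to compound 2 (0.20 log units; within the scatter), shows only that a change at the end of this chain left this assay unchanged beyond the scatter. For compound 3 the expected outcome in this assay is therefore a step of about a 1.3-fold higher number from compound 2 to compound 3 (0.12 log units; within the scatter), not clearly beyond the scatter in either direction. Compound 3 is estimated at 1100 nM in this assay, with a range of 300 nM to 4000 nM.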

Compound 3, half-maximal effective concentration: 1050 nM
Compound 3: the middle estimate sits 1.0-fold (0.02 log units) above what was measured; the measured number falls inside the stated range.
By their numbers in this assay, from the lowest: compounds 2, 3 and 1 (each within the scatter of the next).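

Going by these compounds alone, the step of a 1.3-fold higher number from compound 2 to compound 3 (0.10 log units; within the scatter) in this assay is the first reading on a ring exchange at this chain end: a five-membered aromatic ring with 2 hetero atoms replaces a six-membered aromatic ring of carbon only, on a side chain that also changes from phenethyl to the smaller 1H-pyrazol-1-yl, and the result stays within the scatter. The step of a 1.2-fold lower number from compound 1 to compound 3 (0.10 log units; within the scatter) is also within the scatter, so hydroxymethyl, phenethyl and 1H-pyrazol-1-yl on this saturated chain carbon are not told apart by this read-out, and all three compounds shown sit within the scatter of one another. No data on hand account for this lack of separation.

Whether any group at this chain end moves the number beyond the scatter remains open, since a primary amine, a carboxylic acid or a longer chain ending in 1H-pyrazol-1-yl could behave differently from the three ends shown. Also open, from the compounds shown here alone, is whether the same exchanges give the same result on a core carrying something other than the butylamino and methyl groups of the shared core.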